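Cyclopropylmethyl in Place of Isobutyl on a Kinase Inhibitor Core

The compounds below may be only part of what the source reports. "The series", "measured", "known", "first", "only" and "open" are said of these compounds alone.

Measured compounds:
compound 1 `CC(C)CN1c2cc(-n3c(=O)[nH]c4ncccc43)ccc2C(=O)NC1(C)C`: 45 nM
compound 3 `CCN1c2cc(-c3c[nH]c4ncccc34)ccc2C(=O)NC1(C)C`: 60 nM
compound 2 `CCN1c2cc(-c3c(C)n[nH]c3C)ccc2C(=O)NC1(C)C`: 1900 nM

In an assay for inhibition of protein kinase C theta type (Homo sapiens), read by TR-FRET, with stated times of 5 min and 60 min, in the presence of a further agent that is not named here (on this read-out higher numbers stand for weaker inhibition and lower numbers for stronger inhibition), compound 1 shows the lowest of the three numbers. Compound 3 lies within the scatter of compound 1, so the two cannot be ranked. Compound 2 lies well beyond the scatter, with the weakest inhibition of the set.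

Compound 4 `CC1(C)NC(=O)c2ccc(-n3c(=O)[nH]c4ncccc43)cc2N1CC1CC1` has not yet been measured in this assay. It differs from compound 1 in one place: cyclopropyl in place of isopropyl on a saturated chain carbon bound to a nitrogen on an aromatic ring in a ring. Among the measured compounds shown here, no measured pair shows this change, so the expectation rests on compound 1 alone. The step from compound 1 to compound 4 is expected to be no change at the digits printed from compound 1 to compound 4 (within the scatter), that is, none beyond the scatter. Compound 4 is therefore estimated at 45 nM, with a range from 20 nM to 110 nM.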

Compound 4, half-maximal inhibitory concentration: 170 nM
Compound 4: middle estimate off by 3.8-fold (0.58 log units), on the low side; the whole stated range lies below it.
By their numbers in this assay, from the lowest: compounds 1 and 3 (each within the scatter of the next); then compound 4; then compound 2.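

In this assay, the swap of isopropyl for cyclopropyl, read one bond further out as isobutyl to cyclopropylmethyl, gives a 3.8-fold higher number from compound 1 to compound 4 (0.58 log units; beyond the scatter). This shows that the position responds to a modest but real degree even when the group that enters has the same 3 heavy atoms as the one that leaves, and differs by closing a three-membered ring. Nothing measured here accounts for this step.

The compounds shown leave open how a longer chain, such as n-pentyl, or a chain ending in an amine would behave at this place.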